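Amide nitrogen swap in a weakly cytotoxic ester series

The source may hold more compounds than are shown below. What is called first, only, known or untested is meant among the compounds shown, and "the series" means these compounds.

Compound 1 `COCOc1cc(/C=C/C(=O)OCC(=O)NCc2ccco2)ccc1OCc1ccccc1` is the point of departure. In a functional assay on ECa-109 cells (Homo sapiens) for cytotoxicity, read by MTT assay, with a stated time of 72 h (a lower number here means a stronger inhibitor, a higher number a weaker inhibitor), compound 1 reports only the limit > 200000 nM and no number. Compound 2 `CCOc1ccc(COc2c(OC)cc(/C=C/C(=O)OCC(=O)Nc3ccc(Cl)cc3)cc2OC)cc1` likewise stops at the limit > 200000 nM in this assay. Compound 3 `O=C(COC(=O)/C=C/c1ccc(O)c(O)c1)Nc1ccc(Cl)cc1` gives 175000 nM in this assay, a measured number rather than a limit. Compound 1 therefore stands at the edge of what the assay resolves, and the limit of > 200000 nM in this assay, at which 2 of the 3 values shown sit, shows how much of the set sits there. Compound 4 `COCOc1cc(/C=C/C(=O)OCC(=O)Nc2nccs2)ccc1OCc1ccccc1` is not yet measured; (1,3-thiazol-2-yl in place of (furan-2-yl)methyl on an amide-type nitrogen). Among the compounds with values here, no measured pair in the set differs at this place alone, so there is no precedent for the step. The step from compound 1 to compound 4 in this assay is expected at a number no higher from compound 1 to compound 4 (the limit leaves the size open), no larger than the scatter. Compound 4 is accordingly estimated at 200000 nM, within 90000 nM to 500000 nM, and is expected most likely to return a limit again.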

Compound 4, half-maximal inhibitory concentration: > 200000 nM
Compound 4: only a limit was reported; the forecaster's own chance of this, stated with the estimate: 65%; the middle value lies on the limit itself.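

Compound 1 and compound 4 both end in a limit in this assay, so no step can be read between them: the limit of > 200000 nM in this assay, at which 3 of the 4 values shown sit.

From the compounds shown here alone, whether 1,3-thiazol-2-yl in place of (furan-2-yl)methyl on the amide-type nitrogen changes cytotoxicity at all remains open.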